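The compounds below may be only part of what the source reports. "The series", "measured", "known", "first", "only" and "open" are said of these compounds alone.

Compound 2 `CC(=O)/C(=N\c1ccccc1Cl)NNc1ccccc1C(F)(F)F` gives in an assay on isolated protein for binding affinity to corticotropin-releasing factor receptor 1 (Homo sapiens) (a lower number here means a stronger inhibitor, a higher number a weaker inhibitor), only a limit, > 10000 nM. Compound 1 `CC(=O)/C(=N\c1ccccc1Cl)NNc1ccccc1Cl` likewise gives only a limit in this assay, > 10000 nM. The step from compound 1 to compound 2, a step that the two limits leave unreadable from compound 1 to compound 2, cannot be read because of the limit of > 10000 nM in this assay, at which 2 of the 2 values shown sit. Compound 3 `CC(=O)/C(=N\c1cccc(F)c1)NNc1ccccc1C(F)(F)F` differs from compound 2 by 3-fluorophenyl in place of 2-chlorophenyl on a double-bonded nitrogen. For the measured compounds named here, no measured step touches the group on the double-bonded nitrogen, so neither size nor direction of the change in this assay can be taken from the numbers, and a limit again is the most likely outcome. Compound 3 is expected to give about 10000 nM in this assay, between 2000 nM and 30000 nM, an expected step of a number no higher from compound 2 to compound 3 (the limit leaves the size open).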

Compound 3, inhibition constant: 197 nM
The estimate for compound 3 lay 51-fold (1.71 log units) above the measured number; the whole stated range lies above it.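

Changing the group on the double-bonded nitrogen moves the result in this assay: 3-fluorophenyl in place of 2-chlorophenyl gives an at least 50-fold lower number from compound 2 to compound 3 (1.70 log units; beyond the scatter). Compound 3 is the only one of the three with a measured number instead of a limit, so this position can shift binding strongly.

The compounds do not separate the change of halogen from its change of ring position, and how a phenyl ring carrying an amine or a carboxylic acid would behave here is open. The full size of the step is also open because compound 2 gives only a limit: the limit of > 10000 nM in this assay, at which 2 of the 3 values shown sit.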